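From fluoro to trifluoromethyl in a two-compound series

A few compounds are considered here, and "the series" means these few. Any claim that something is new, unique, unknown or untested is made for them only; others in the source may bear on it.

Measured in an ADME assay on cells (Hepatocyte, Mus musculus) for cytotoxicity, read by MTT assay, with a stated time of 24 h; on this read-out higher numbers stand for lower toxicity in this test and lower numbers for higher toxicity in this test
compound 1 `COc1ccc(S(=O)(=O)n2c(-c3cn(-c4ccccc4)nc3-c3ccc(F)cc3)nc3ccccc32)cc1` gives 105000 nM
compound 2 `O=[N+]([O-])c1ccc(S(=O)(=O)n2c(-c3cn(-c4ccccc4)nc3-c3ccc(F)cc3)nc3ccccc32)cc1` gives > 300000 nM as a limit

Compound 2 has no exact value on this scale: its reading (> 300000 nM) is a limit of the assay and not a number.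

Compound 3 `O=[N+]([O-])c1ccc(S(=O)(=O)n2c(-c3cn(-c4ccccc4)nc3-c3ccc(C(F)(F)F)cc3)nc3ccccc32)cc1` has trifluoromethyl in place of fluoro on an aromatic carbon and is otherwise the same as compound 2. The change sits para to a large group.

Among the measured compounds shown here, the only measured step (an at least 2.8-fold higher number from compound 1 to compound 2 (0.45 log units; beyond the scatter)) is nitro in place of methoxy. It lies at a different place and gives no direct size for this change, so it bears on it only weakly. No step beyond the scatter is therefore expected in this assay and no direction is favoured.

The expected step is small (a number no higher from compound 2 to compound 3 (the limit leaves the size open)) and may again be hidden by the limit.

For compound 3 the estimate is 300000 nM (expected range 130000 nM to 600000 nM).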

Compound 3, half-maximal cytotoxic concentration: 178000 nM
The estimate for compound 3 lay 1.7-fold (0.23 log units) above the measured number; low and high end bracket the measured number.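

In this assay, among the compounds shown here, compound 3 gives 178000 nM, the first exact number for a compound carrying the nitro group, and the first reading at the position para to a large group. Trifluoromethyl in place of fluoro gives an at least 1.6-fold lower number from compound 2 to compound 3 (0.22 log units; that floor lies within the scatter). The direction can be read from this, but the true size stays open because one end of the step is a limit and not a number: the limit of > 300000 nM in this assay, at which 1 of the 3 values shown sits.

This change is read separately from nitro in place of methoxy, which lies at a different place and gives an at least 2.8-fold higher number from compound 1 to compound 2 (0.45 log units; beyond the scatter). Open, on these data alone, is how an amine, a carboxylic acid or a longer chain in place of fluoro would read at this position. Also open, as far as these compounds go, is whether the 4-fluorophenyl to 4-(trifluoromethyl)phenyl change keeps its direction with methoxy in place of nitro.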